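Replacing one sulfonyl substituent of compound 2

The source may hold more compounds than are shown below. What is called first, only, known or untested is meant among the compounds shown, and "the series" means these compounds.

Measured so far in a functional assay on BXPC-3 cells (Homo sapiens) for inhibition, read by MTT assay, with a stated time of 7 days; a lower number here means a stronger inhibitor, a higher number a weaker inhibitor:
compound 1 `CCN(CC)S(=O)(=O)c1ccc(S(=O)(=O)N2CCC[C@@H](C(=O)N[C@H]3CC[C@H](OC)CC3)C2)cc1`: 2000 nM
compound 2 `O=C([C@@H]1CCCN(S(=O)(=O)c2ccc(S(=O)(=O)N3CC[C@@H](O)C3)cc2)C1)N1CCC(F)(F)CC1`: 330 nM

Of these two, compound 2 has the lower number and is therefore the stronger inhibitor, by more than the usual scatter. The next compound to be tested is compound 3 `O=C([C@@H]1CCCN(S(=O)(=O)c2ccc(S(=O)(=O)C3COC3)cc2)C1)N1CCC(F)(F)CC1`, which carries oxetan-3-yl in place of 3-hydroxypyrrolidin-1-yl on a sulfonyl sulfur. Within the data shown here, compounds 1 and 2 differ in more than one place, so no measured step shows the effect of this swap. In this assay a small move is expected, a 1.5-fold higher number from compound 2 to compound 3 (0.18 log units; within the scatter) as estimated, towards a weaker inhibitor and probably within the scatter. For compound 3 the estimate is 500 nM (expected range 130 nM to 1900 nM).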

Compound 3, half-maximal inhibitory concentration: 361 nM
Compound 3: middle estimate off by 1.4-fold (0.14 log units), on the high side; measured number inside the range.
By their numbers in this assay, from the lowest: compounds 2 and 3 (each within the scatter of the next); then compound 1.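

In this assay the change on this sulfonyl sulfur gives a 1.1-fold higher number from compound 2 to compound 3 (0.04 log units; within the scatter) and so leaves the two compounds indistinguishable. In this pair, the read-out holds with oxetan-3-yl, which has no hydrogen-bond donor or defined stereocentre, in place of 3-hydroxypyrrolidin-1-yl, which has both. No measurement here explains why the two groups read alike. From the compounds shown here alone, how an open-chain amine or a carboxylic acid would read on this sulfonyl sulfur stays open. Also open, going by these compounds, is whether this swap would read the same with the amide group of compound 1.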